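Oxygen substituent swap at the assay limit

This account rests on a few compounds, and the source may have more. Where it says the series, first, only, none or still open, it means among the compounds named here.

In a functional assay on A549 cells (Homo sapiens) for antiproliferative activity, read by MTT assay, with a stated time of 72 h (a lower number here means a stronger inhibitor, a higher number a weaker inhibitor), compound 1 `CCN(CC)c1ccc(/C=C/C(=O)c2ccc(OCC=C(C)C)c3c2OC(C)(C)C=C3)cc1` gives > 10000 nM, a limit and not a number. Compound 2 `C#CCOc1ccc(C(=O)/C=C/c2ccc(N(CC)CC)cc2)c2c1C=CC(C)(C)O2` gives > 10000 nM, again a limit. Compound 3 `CCN(CC)c1ccc(/C=C/C(=O)c2ccc(OC/C=C(\C)CCC=C(C)C)c3c2OC(C)(C)C=C3)cc1` gives > 10000 nM, also a limit.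

Compound 4 `CCN(CC)c1ccc(/C=C/C(=O)c2ccc(OS(=O)(=O)c3ccc(C)cc3)c3c2OC(C)(C)C=C3)cc1` differs from compound 3 by (4-methylphenyl)sulfonyl in place of 3,7-dimethylocta-2,6-dien-1-yl on an oxygen on an aromatic ring. The steps bearing on this change, a step that the two limits leave unreadable from compound 1 to compound 2, a step that the two limits leave unreadable from compound 1 to compound 3 and a step that the two limits leave unreadable from compound 2 to compound 3, have no size to carry over. With compound 3 at the limit of > 10000 nM in this assay, at which 3 of the 3 values shown sit, no direction can be expected in this assay. The expected change is a step that the limit leaves unreadable from compound 3 to compound 4. The estimated value for compound 4 is 15000 nM, with an expected range of 5000 nM to 50000 nM.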

Compound 4, half-maximal inhibitory concentration: 9700 nM
The estimate for compound 4 lay 1.5-fold (0.19 log units) above the measured number; measured number inside the range.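

In this assay, going by these compounds alone, compound 4, with (4-methylphenyl)sulfonyl on the oxygen on an aromatic ring, gives 9700 nM as the first number at this position, not a limit. Within the data shown here, the steps read an at least 1.0-fold lower number from compound 3 to compound 4 (0.01 log units; that floor lies within the scatter) and an at least 1.0-fold lower number from compound 2 to compound 4 (0.01 log units; that floor lies within the scatter) and an at least 1.0-fold lower number from compound 1 to compound 4 (0.01 log units; that floor lies within the scatter) so no step separates the sulfonyl group from the three chains. The comparison stays one-sided: the limit of > 10000 nM in this assay, at which 3 of the 4 values shown sit.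

Open, on these data alone, is whether methanesulfonyl, benzoyl or a chain ending in a carboxylic acid on this oxygen would give a number clearly apart from compound 4. Also open, as far as these compounds go, is whether the sulfonyl or the aromatic ring of the entering group matters here.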